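Sulfonyl aryl variation on the methylpiperidinyl quinoline series

This account rests on a few compounds, and the source may have more. Where it says the series, first, only, none or still open, it means among the compounds named here.

Three compounds of the series have numbers in an assay on isolated protein for displacement of a labelled ligand from metabotropic glutamate receptor 5 (Homo sapiens), with a stated time of 60 min, tested at 1 uM; on this read-out lower numbers stand for less inhibition and higher numbers for more inhibition at the one concentration tested (going by the name of the read-out). Compound 1 `CC1CCN(c2c(S(=O)(=O)c3ccccc3)cnc3cc(Cl)ccc23)CC1` gives 93%. Compound 2 `Cc1ccc2ncc(S(=O)(=O)c3ccc(F)cc3)c(N3CCC(C)CC3)c2c1` gives 90%, which places compound 2 second of the three, between compound 1 and compound 3; both gaps lie within the scatter, so no order among them can be read. Compound 3 `CC1CCN(c2c(S(=O)(=O)c3ccc(F)cc3)cnc3ccc(F)cc23)CC1` gives 87%. Among the measured compounds shown here, the one single-point step in the set, a number 3 percentage points lower from compound 2 to compound 3 (within the scatter), changes the core aromatic substituent and leaves the sulfonyl aryl untouched.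

Compound 4 `Cc1ccc2ncc(S(=O)(=O)c3cc(Cl)cc(Cl)c3)c(N3CCC(C)CC3)c2c1` is not yet measured. Relative to compound 2 the change is 3,5-dichlorophenyl in place of 4-fluorophenyl on a sulfonyl sulfur. For the measured compounds named here, no measured step touches the group on the sulfonyl sulfur, so none bears directly on this change; compound 1 and compound 2 differ in more than one place and no step between them is given. What the three numbers show is that the read-out stays high across the variations seen, with the largest gap among them within the scatter.

On that basis compound 4 is expected to stay in the same high band, with a step of a number 5 percentage points lower from compound 2 to compound 4 (within the scatter) that is expected to be small or none beyond the scatter. The estimate for compound 4 is 85%, with a range from 60% to 97%. Going by the values given here, the lower end is set wide: the sulfonyl aryl has not been varied among the measured compounds, so no measured step shows how this position responds.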

Compound 4, a percentage reported as inhibition, at one concentration (the size of the read-out at that concentration, not a potency): 75%
Compound 4: middle estimate off by 10 percentage points, on the high side; low and high end bracket the measured number.
By their numbers in this assay, from the lowest: compound 4; then compounds 3, 2 and 1 (each within the scatter of the next).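

Among the compounds shown here, the group on the sulfonyl sulfur is the first place where a single change moves the number beyond the scatter: in this assay, 3,5-dichlorophenyl in place of 4-fluorophenyl gives a number 15 percentage points lower from compound 2 to compound 4 (beyond the scatter). For the compounds shown here, the only other single-place step, a number 3 percentage points lower from compound 2 to compound 3 (within the scatter), changes a core substituent instead, so the sulfonyl aryl is now the one position with a step beyond the scatter, although the step is modest and compound 4 still gives 75% at the one concentration tested. Nothing available accounts for this step, which stands as an observation only.

Going by these compounds, with one pair on the core of compound 2, it remains open whether the lower number goes with the departure of 4-fluorophenyl, the arrival of 3,5-dichlorophenyl, or both. On these data alone, how the position responds to other groups on the sulfonyl sulfur, such as a monochlorophenyl, a methoxyphenyl, a pyridine ring or a simple alkyl chain, also remains open, as does whether a step of this size would hold up in a full concentration series.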